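This account rests on a few compounds, and the source may have more. Where it says the series, first, only, none or still open, it means among the compounds named here.

Measured so far:
Compound 1, `CC(Sc1nc2c(cnn2C)c(=O)n1-c1ccc(CO)cc1)c1ccccc1`: 600 nM
Compound 2, `C[C@@H](Sc1nc2c(cnn2C)c(=O)n1-c1ccccc1)c1ccccc1`: 40 nM

In an assay on isolated protein for inhibition of retinal dehydrogenase 2 (Homo sapiens) (on this read-out lower numbers stand for stronger inhibition and higher numbers for weaker inhibition), compound 1 gives 600 nM, the higher of the two numbers; compound 2 gives 40 nM, a markedly lower number and therefore a stronger inhibitor. Compound 3, `CC(Sc1nc2c(cnn2C)c(=O)n1-c1ccc(C#N)cc1)c1ccccc1`, has not yet been measured. It differs from compound 1 by cyano in place of hydroxymethyl on an aromatic carbon. Among the compounds with values here, no measured pair shows this exact exchange, so the expected step is a guess: a modest move from compound 1 to compound 3 of a 1.5-fold lower number from compound 1 to compound 3 (0.18 log units; within the scatter) toward a lower number, close to the scatter. Compound 3 is estimated at 400 nM, with a range from 120 nM to 1500 nM.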

Compound 3, half-maximal inhibitory concentration: 3100 nM
Beside the measured number, compound 3's estimate is 7.8-fold (0.89 log units) below it; the measured number lies above the stated range.
By their numbers in this assay, from the lowest: compound 2; then compound 1; then compound 3.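

In this assay, this position, on an aromatic carbon para to a large group, is sensitive to what sits there: cyano in place of hydroxymethyl gives a 5.2-fold higher number from compound 1 to compound 3 (0.71 log units; beyond the scatter) and so a weaker inhibitor. The two groups have the same count of heavy atoms, but hydroxymethyl carries a hydrogen-bond donor and cyano carries none. Nothing available explains the step.

Going by these compounds, whether that donor matters remains open, and so does how an amine or a carboxylic acid would fare at this position.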